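A few compounds are considered here, and "the series" means these few. Any claim that something is new, unique, unknown or untested is made for them only; others in the source may bear on it.

Compounds measured in a functional assay on MCF7 cells (Homo sapiens) for antiproliferative activity, read by sulforhodamine B assay, with a stated time of 48 h; a higher number here means a weaker inhibitor of growth, a lower number a stronger inhibitor of growth: compound 1 `COc1ccc(-c2cc(N3CCC(CNS(N)(=O)=O)CC3)ncn2)cc1` gives 35300 nM; compound 2 `NS(=O)(=O)NCC1CCN(c2cc(-c3ccc(C(F)(F)F)cc3)ncn2)CC1` gives 22500 nM; compound 3 `CCOC(=O)c1ccc(-c2cc(N3CCC(CNS(N)(=O)=O)CC3)ncn2)cc1` gives 4100 nM.

Compound 1 stands at the highest of these three numbers; compound 2 lies close, a 1.6-fold lower number from compound 1 to compound 2 (0.20 log units; within the scatter), while compound 3 lies furthest, an 8.6-fold lower number from compound 1 to compound 3 (0.93 log units; beyond the scatter). The change from compound 1 to compound 4 `COc1ccccc1-c1cc(N2CCC(CNS(N)(=O)=O)CC2)ncn1` is 2-methoxyphenyl in place of 4-methoxyphenyl on an aromatic carbon. Among the compounds with values here, no measured step bears directly on it: the steps known, a 1.6-fold lower number from compound 1 to compound 2 (0.20 log units; within the scatter) and a 5.5-fold lower number from compound 2 to compound 3 (0.74 log units; beyond the scatter), swap one group for another on the shared core rather than move the same group. He therefore expects no step beyond the scatter in this assay, a 1.0-fold lower number from compound 1 to compound 4 (0.00 log units; within the scatter). Compound 4 is estimated at 35000 nM, in the range 12000 nM to 100000 nM.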

Compound 4, concentration for 50% growth inhibition: 10100 nM
Compound 4: middle estimate off by 3.5-fold (0.54 log units), on the high side; measured number outside the range, below it.
By their numbers in this assay, from the lowest: compound 3; then compound 4; then compounds 2 and 1 (each within the scatter of the next).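

Moving the methoxy group alone, with the same atoms, gives a 3.5-fold lower number from compound 1 to compound 4 (0.54 log units; beyond the scatter) in this assay, so 2-methoxyphenyl in place of 4-methoxyphenyl changes the reading beyond the scatter. Within the data shown here, the earlier compounds showed only swaps of one group for another; this is the first sign that where the methoxy sits counts, not only which group is present. No measurement given here accounts for the shift. Going by these compounds, whether trifluoromethyl or ethoxycarbonyl would respond in the same way to such a move stays open, as does what an amine or a carboxylic acid would give at this place.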